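A few compounds are considered here, and "the series" means these few. Any claim that something is new, unique, unknown or untested is made for them only; others in the source may bear on it.

Two compounds of this series have numbers in hand. Compound 1 `COc1ccc(C(=O)O)cc1OC[C@@H](C)COc1ccc(C(=O)CC(C)(C)C)c(O)c1C` gives, in an assay for positive allosteric modulation of metabotropic glutamate receptor 3 (Rattus norvegicus) (on this read-out higher numbers stand for an effect only at larger amounts of compound and lower numbers for an effect already at smaller amounts), a value of 1040 nM. Compound 2 `Cc1c(OC[C@@H](C)COc2ccc(C(=O)O)cc2F)ccc(C(=O)CC(C)(C)C)c1O` gives in this assay a value of 1300 nM. Compound 2 thus holds the highest of the two numbers, yet its nearest neighbour is compound 1, and the gap between them lies within the usual scatter of the measurement, so the two cannot be told apart.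

Compound 3 `COc1cccc(OC[C@H](C)COc2ccc(C(=O)CC(C)(C)C)c(O)c2C)c1` has not yet been measured. It differs from compound 2 in one place: 3-methoxyphenyl in place of 4-carboxy-2-fluorophenyl on an oxygen on a saturated carbon. The acid group that both measured compounds carry is thereby given up, and nothing among the two measured compounds shows what that costs or gains. The expected step from compound 2 to compound 3 in this assay is a 1.5-fold higher number from compound 2 to compound 3 (0.16 log units; within the scatter), a modest move toward larger amounts that may well stay within the scatter. For compound 3 the estimate in this assay is 1900 nM, with a range from 500 nM to 7000 nM.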

Compound 3, half-maximal effective concentration: "not active" (no number reported)
No number was reported for compound 3, and the estimate cannot be compared.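

Within the data shown here, compound 3 is reported in this assay as "not active" without a number, so no step from compound 2 to compound 3 can be read. Nothing shown offers an explanation for this result. The compounds shown leave open whether giving up the acid group alone decides this outcome.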